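This account rests on a few compounds, and the source may have more. Where it says the series, first, only, none or still open, it means among the compounds named here.

Working notes on the series in an ADME assay on Huh-7 cells (Homo sapiens) for cytotoxicity, with a stated time of 72 h (a higher number here means that more compound is tolerated, a lower number that less compound is tolerated), follow. Compound 1 `CC(C)CCn1nc(-c2cccs2)c(O)c(C2=NS(=O)(=O)c3cc(NS(=O)(=O)C4CC4)ccc3N2)c1=O` gives > 1000 nM here as a limit of the assay and not a number. Compound 2 `CC(C)CCn1nc(-c2cccs2)c(O)c(C2=NS(=O)(=O)c3cc(N(C)S(C)(=O)=O)ccc3N2)c1=O` gives > 33000 nM as a limit as well. Compound 3 `CC(C)CCn1nc(C2CCCCC2)c(O)c(C2=NS(=O)(=O)c3cc(NS(C)(=O)=O)ccc3N2)c1=O` gives > 1000 nM as a limit too, so its standing is known only as a limit. All three results are limits, with the values sitting at the limit of > 1000 nM in this assay, at which 2 of the 3 values shown sit, and at the limit of > 33000 nM in this assay, at which 1 of the 3 values shown sits, and no number among them. The next compound is compound 4 `CC(C)CCn1nc(C2=CCCC2)c(O)c(C2=NS(=O)(=O)c3cc(NS(C)(=O)=O)ccc3N2)c1=O` and the change is cyclopent-1-en-1-yl in place of cyclohexyl on an aromatic carbon with cyclopent-1-en-1-yl in place of cyclohexyl on an aromatic carbon. Among the measured compounds shown here, the only measured step is a step that the two limits leave unreadable from compound 1 to compound 2 and it concerns another place on the molecule, so it gives no size to carry over. No step beyond the scatter is therefore expected in this assay and the estimated change is a step that the limit leaves unreadable from compound 3 to compound 4 in no firm direction. Compound 4 is estimated at 15000 nM with an expected range of 2000 nM to 50000 nM and will quite likely be reported only as a limit.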

Compound 4, half-maximal cytotoxic concentration: > 1000 nM
Compound 4 was reported as a limit; the forecaster's own chance of this, stated with the estimate: 85%; the middle value lies beyond the limit too.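

In this assay, among the compounds shown here, compound 3 and compound 4 are both reported only as limits of the assay, so no step between them can be read. The compounds shown leave open whether cyclopent-1-en-1-yl in place of cyclohexyl changes the tolerated concentration at all.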